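The source may report more compounds than this note shows. Statements on the series, on what has been measured and on what is new or still open speak of the compounds shown alone.

Working notes, sulfonamide series, a functional assay on DLD-1 cells (Homo sapiens) for antiproliferative activity, read by CellTiter-Glo, with a stated time of 72 h; a higher number here means a weaker inhibitor, a lower number a stronger inhibitor.

Three compounds share a core and differ only in the group on the sulfonyl sulfur. Compound 1 `CC1CCN(C2CCN(S(=O)(=O)c3ccc(C#N)cc3)CC2)CC1` gives 2800 nM in this assay. Compound 2 `CC1CCN(C2CCN(S(=O)(=O)c3cnc(Cl)s3)CC2)CC1` gives 1800 nM; the step of a 1.6-fold lower number from compound 1 to compound 2 (0.19 log units; within the scatter) is small. Compound 3 `Cc1cccc(S(=O)(=O)N2CCC(N3CCC(C)CC3)CC2)c1` gives 25 nM, the lowest of the three numbers, with a 110-fold lower number from compound 1 to compound 3 (2.05 log units; beyond the scatter) and a 72-fold lower number from compound 2 to compound 3 (1.86 log units; beyond the scatter) both large steps.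

Compound 4 `CC1CCN(C2CCN(S(=O)(=O)c3cccnc3F)CC2)CC1` is not yet measured. It differs from compound 3 by 2-fluoropyridin-3-yl in place of 3-methylphenyl on a sulfonyl sulfur. Going by the values given here, no measured step swaps one six-membered aromatic group for another; the two steps that bear on it, from compound 1 and from compound 2 to compound 3, show that exchanging the group on the sulfonyl sulfur can move the number by a large amount. Both groups that gave high numbers are otherwise unrelated to the entering group, so the direction for compound 4 is open; the middle estimate is set between compound 3 and the two weaker compounds. Compound 4 is therefore expected to show a 10-fold higher number from compound 3 to compound 4 (1.00 log units; beyond the scatter), a rise from compound 3, with wide uncertainty. The estimate for compound 4 is 250 nM, in a range from 40 nM to 1600 nM.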

Compound 4, half-maximal inhibitory concentration: > 5000 nM
Compound 4: no number, only a limit (the forecaster's own chance of this, stated with the estimate: 3%); middle value at least 20-fold (1.30 log units) from the limit.
By their numbers in this assay, from the lowest: compound 3; then compounds 2 and 1 (each within the scatter of the next). At a limit, above all of these: compound 4.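

In this assay compound 4 reads > 5000 nM, which is a limit of the assay and not a number: the limit of > 5000 nM in this assay, at which 1 of the 4 values shown sits.

Going by these compounds alone, the exchange at the sulfonyl sulfur keeps the heavy-atom count and a single six-membered aromatic ring, yet the step is large (an at least 200-fold higher number from compound 3 to compound 4 (2.30 log units; beyond the scatter)), so the earlier steps, which all involved 4-cyanophenyl or 2-chloro-1,3-thiazol-5-yl, are joined by one showing that an equal count and the same ring size do not preserve the low number of compound 3. The remaining steps place compound 3 alone at the low end of the series: the floor of the step to compound 4 from the thiazole compound lies beyond the scatter (an at least 2.7-fold higher number from compound 2 to compound 4 (0.44 log units; beyond the scatter)), while the floor of the step from the nitrile compound lies within it (an at least 1.7-fold higher number from compound 1 to compound 4 (0.25 log units; that floor lies within the scatter)), so no order between those two compounds can be claimed.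

The compounds shown do not separate the contribution of the ring nitrogen from that of the fluorine, or either from the loss of the methyl group. From the compounds shown here alone, how a plain phenyl, a 3-fluorophenyl or a pyridin-3-yl group would read on the same sulfonyl sulfur stays open.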